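This account rests on a few compounds, and the source may have more. Where it says the series, first, only, none or still open, it means among the compounds named here.

In an assay on isolated protein for inhibition of myosin-2 (Bos taurus), read by spectrophotometry, with a stated time of 24 min (a lower number here means a stronger inhibitor, a higher number a weaker inhibitor), compound 1 `C/C(=N\Cc1ccccc1)c1c(O)c2ccccc2[nH]c1=O` gives >= 100000 nM, which is a limit of the assay rather than a number. Compound 2 `C/C(=N\CCO)c1c(O)c2ccccc2[nH]c1=O` gives >= 100000 nM in this assay, again a limit. Compound 3 `C/C(=N\Cc1ccccc1C)c1c(O)c2ccccc2oc1=O` gives >= 100000 nM, also a limit. The step from compound 1 to compound 2, a hydroxymethyl in place of phenyl on a saturated chain carbon bound to a double-bonded nitrogen, reads a step that the two limits leave unreadable from compound 1 to compound 2. All three measured compounds sit at the limit of >= 100000 nM in this assay, at which 3 of the 3 values shown sit, so compound 2 stands no differently from the others on the numbers shown. Compound 4 `CCCCC/N=C(\C)c1c(O)c2ccccc2[nH]c1=O` is not yet measured; it differs from compound 2 by propyl in place of hydroxy on a saturated chain carbon, two bonds along the chain from a double-bonded nitrogen. Among the measured compounds shown here, the one measured step that touches this part of the molecule, from compound 1 to compound 2, is unreadable, and no measured compound gives a number to anchor the change. The expectation for compound 4 is therefore a step of a number no higher from compound 2 to compound 4 (the limit leaves the size open), meaning compound 4 is expected to remain at the limit. Compound 4 is estimated at 100000 nM, with a range from 30000 nM to 300000 nM.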

Compound 4, half-maximal inhibitory concentration: >= 100000 nM
Compound 4 ended at the assay's limit; the forecaster's own chance of this, stated with the estimate: 80%; the middle value sits exactly at the limit.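

Compound 4 gives >= 100000 nM, a limit of the assay and not a number, so its steps from compound 1 and from compound 2 cannot be read. The compounds shown leave open which change, if any, would give a readable number in this assay, as all remain at one limit: the limit of >= 100000 nM in this assay, at which 4 of the 4 values shown sit.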